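The source may hold more compounds than are shown below. What is called first, only, known or untested is meant among the compounds shown, and "the series" means these compounds.

Working notes on the series at the amide-bearing aryl amine.

Compound 1 `CCN(Cc1ccccn1)c1cccc(C(=O)N2CCc3ccc(OS(N)(=O)=O)cc3C2)c1` gives 6.5% in an assay on HEK293 cells for inhibition of Steryl-sulfatase (Homo sapiens), tested at 0.1 uM; a lower number here means a weaker effect, a higher number a stronger effect of the compound at the concentration tested. Compound 2 `CC(C)CCN(CCC(C)C)c1cccc(C(=O)N2CCc3ccc(OS(N)(=O)=O)cc3C2)c1` gives 32.3%. Compound 3 `CCN(Cc1ccc(F)cc1)c1cccc(C(=O)N2CCc3ccc(OS(N)(=O)=O)cc3C2)c1` gives 10.9%, the second highest of the three numbers: its nearest neighbour is compound 1, with a number 4.4 percentage points higher from compound 1 to compound 3 (within the scatter), and its furthest is compound 2, with a number 21.4 percentage points lower from compound 2 to compound 3 (beyond the scatter). Within the data shown here, the one step that clearly moves the read-out, a number 25.8 percentage points higher from compound 1 to compound 2 (beyond the scatter), replaces the whole amino substituent.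

Compound 4 `CCN(Cc1ccc(Br)cc1)c1cccc(C(=O)N2CCc3ccc(OS(N)(=O)=O)cc3C2)c1` differs from compound 3 only by bromo in place of fluoro on an aromatic carbon. Among the measured compounds shown here, no measured step exchanges one halogen for another; the nearest precedent, the within-scatter move from compound 1 to compound 3, swaps a ring with a ring. The larger steps, between compound 2 and each of the others, replace the entire substituent on the aryl nitrogen and do not bear on a single halogen swap. A step of a number 3.1 percentage points higher from compound 3 to compound 4 (within the scatter) is therefore expected, within the scatter. Compound 4 is estimated at 14%, in the range 4% to 30%.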

Compound 4, a percentage reported as inhibition, at one concentration (the size of the read-out at that concentration, not a potency): 24.2%
The estimate for compound 4 lay 10.2 percentage points below the measured number; the range from low to high includes it.
By their numbers in this assay, from the lowest: compounds 1 and 3 (each within the scatter of the next); then compounds 4 and 2 (each within the scatter of the next).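

The bromo in place of fluoro on an aromatic carbon, para to a large group, is the first single-atom change shown to move the read-out in this assay, with a number 13.3 percentage points higher from compound 3 to compound 4 (beyond the scatter). That one atom covers ground that earlier took replacing the whole amino substituent: a number 17.7 percentage points higher from compound 1 to compound 4 (beyond the scatter), while a number 8.1 percentage points lower from compound 2 to compound 4 (within the scatter), so the (4-bromobenzyl)(ethyl)amino group and the diisopentylamino group cannot be told apart here. Nothing measured accounts for the gain seen with bromo.

As far as these compounds go, what chloro, iodo or a methoxy group would give at this place remains open. Also open, from the compounds shown here alone, is whether the bromo step carries over to the pyridin-2-yl ring, or to a longer chain in place of the ethyl group on the aryl nitrogen.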